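Cyanophenyl Analogue in the Fibroblast Cytotoxicity Series

The source may hold more compounds than are shown below. What is called first, only, known or untested is meant among the compounds shown, and "the series" means these compounds.

Measured compounds:
compound 1, `COC(=O)c1ccc(NCc2cncn2Cc2ccc(Cl)cc2)cc1-c1ccccc1`, 25000 nM;
compound 2, `COC(=O)c1ccc(NCc2cncn2Cc2ccccc2C)cc1-c1ccccc1`, 10000 nM;
compound 3, `COC(=O)c1ccc(NCc2cncn2Cc2ccccc2F)cc1-c1ccccc1`, "not determined" (no result reported).

The three measured compounds share one core and differ only in the group carried on a saturated chain carbon bound to an aromatic nitrogen. In a toxicity assay on NIH3T3 cells (Mus musculus) for cytotoxicity, read by resazurin assay (on this read-out lower numbers stand for an effect already at smaller amounts and higher numbers for an effect only at larger amounts of compound), compound 1 gives 25000 nM, and compound 2 gives 10000 nM. Within the data shown here, the one measured step, a 2.5-fold lower number from compound 1 to compound 2 (0.40 log units; beyond the scatter), is the only guide to how this part of the molecule moves the read-out. In this assay compound 3 gives "not determined" (no result reported), so it stands without a number.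

Compound 4, `COC(=O)c1ccc(NCc2cncn2Cc2cccc(C#N)c2)cc1-c1ccccc1`, differs from compound 3 by 3-cyanophenyl in place of 2-fluorophenyl on a saturated chain carbon bound to an aromatic nitrogen. Since compound 3 has no value, no step can be expected for it; the estimate for compound 4 rests on compounds 1 and 2 alone, which differ in the same position and stay within a modest band of one another. Compound 4 is therefore expected to fall near that band, at about 15000 nM, within 5000 nM to 50000 nM.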

Compound 4, half-maximal effective concentration: > 10000 nM
Compound 4: no number, only a limit (the forecaster's own chance of this, stated with the estimate: 30%); the middle value lies beyond the limit too.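

In this assay compound 4 is reported as > 10000 nM, which is a limit and not a number. With 3-cyanophenyl on a saturated chain carbon bound to an aromatic nitrogen, the series now shows a number no lower from compound 2 to compound 4 (the limit leaves the size open), so this change does not bring the read-out under that of the 2-methylphenyl compound, while the step between compound 1 and compound 4 cannot be read. The reading of this position therefore rests on a limit and not on a further number: the limit of > 10000 nM in this assay, at which 1 of the 4 values shown sits.

The compounds shown leave open how far the true value of compound 4 lies from those of compound 1 and compound 2. They also leave open whether an amine or a carboxylic acid in place of the 3-cyanophenyl group would move the read-out at this position.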